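A few compounds are considered here, and "the series" means these few. Any claim that something is new, unique, unknown or untested is made for them only; others in the source may bear on it.

Measured compounds:
Compound 1 `O=C1C(=O)N(Cc2cn(CC(=O)N3CCOCC3)nn2)c2c(Cl)ccc(Cl)c21`: in a toxicity assay on GES1 cells (Homo sapiens) for inhibition, read by CCK-8 assay, with a stated time of 72 h (on this read-out higher numbers stand for weaker inhibition and lower numbers for stronger inhibition), compound 1 reaches only a limit of the assay, > 128000 nM.
Compound 2 `O=C(Cn1cc(CN2C(=O)C(=O)c3c(Cl)ccc(Cl)c32)nn1)NC1CCCCC1`: in this assay compound 2 gives 47400 nM.

Compound 2 holds the only actual number shown in this assay; the other value, for compound 1, is a limit (the limit of > 128000 nM in this assay, at which 1 of the 2 values shown sits). Within the data shown here, one measured step bears on what follows: an at least 2.7-fold lower number from compound 1 to compound 2 (0.43 log units; beyond the scatter), where a cyclohexylamino took the place of a morpholin-4-yl on a carbonyl carbon. Compound 3 `O=C1C(=O)N(Cc2cn(CC(=O)N3CCCCC3)nn2)c2c(Cl)ccc(Cl)c21` differs from compound 2 in that (piperidin-1-yl in place of cyclohexylamino on a carbonyl carbon). This change removes the hydrogen-bond donor that compound 2 carries and compound 1 lacks, so it runs against the direction seen in an at least 2.7-fold lower number from compound 1 to compound 2 (0.43 log units; beyond the scatter). In this assay the expected step is therefore an increase, a 2.1-fold higher number from compound 2 to compound 3 (0.32 log units; beyond the scatter), toward weaker inhibition. Compound 3 is estimated at 100000 nM, with a range from 40000 nM to 250000 nM, and a fair chance that only a limit is reported.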

Compound 3, half-maximal inhibitory concentration: 50700 nM
For compound 3 the middle estimate is 2.0-fold (0.29 log units) above the measured one; low and high end bracket the measured number.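

With piperidin-1-yl in place of cyclohexylamino on the carbonyl carbon, this assay shows a 1.1-fold higher number from compound 2 to compound 3 (0.03 log units; within the scatter), so the loss of the amide hydrogen of compound 2 leaves no visible mark at this position. Compound 1 and compound 3 both carry no hydrogen-bond donor here, yet the comparison gives an at least 2.5-fold lower number from compound 1 to compound 3 (0.40 log units; beyond the scatter), so the donor alone does not separate these compounds, and the difference goes with morpholin-4-yl against piperidin-1-yl. As far as these compounds go, the full size of that difference stays unknown because compound 1 stands at a limit: the limit of > 128000 nM in this assay, at which 1 of the 3 values shown sits.

From the compounds shown here alone, what remains open is how a smaller ring such as pyrrolidin-1-yl, or an open chain such as diethylamino, would read on the same carbonyl carbon. Also open, going by these compounds, is whether a piperazin-1-yl would fall with morpholin-4-yl or with piperidin-1-yl.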